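From compound 1 to compound 3: a smaller group on the ring

The source may report more compounds than this note shows. Statements on the series, on what has been measured and on what is new or still open speak of the compounds shown alone.

- compound 1 `COc1ccc(N(C)c2nc(C)nc3ccccc23)cc1C(=O)OCC[Se]C#N` gives 890 nM
- compound 2 `COc1ccc(N(C)c2nc(C)nc3ccccc23)cc1C(=O)OCCCC[Se]C#N` gives 975 nM

Among the compounds with values here, in a functional assay on HepG2 cells (Homo sapiens) for inhibition, read by MTT assay, with a stated time of 48 h (a higher number here means a weaker inhibitor, a lower number a stronger inhibitor), compound 1 gives 890 nM and compound 2 gives 975 nM, so compound 1 stands level with the only other measured compound. Within the data shown here, the one measured step confirms this: a 1.1-fold higher number from compound 1 to compound 2 (0.04 log units; within the scatter).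

Compound 3 `COc1ccc(N(C)c2nc(C)nc3ccccc23)cc1OCC[Se]C#N` has not been measured yet. Reaching it from compound 1 takes this change: a group of 6 heavy atoms (3 carbon, 1 nitrogen, 1 oxygen, 1 selenium; no ring) in place of a group of 8 heavy atoms (4 carbon, 1 nitrogen, 2 oxygen, 1 selenium; no ring), on an aromatic carbon. The swap sits on an aromatic carbon of a six-membered aromatic ring of carbon only, ortho to a methoxy group, and it removes the carbonyl group.

Among the measured compounds shown here, the measured step changed a saturated chain carbon and left this aromatic carbon alone, so it is only a weak guide, and no measured step tests the swap itself. Since the chain change gave just a 1.1-fold higher number from compound 1 to compound 2 (0.04 log units; within the scatter) in this assay, no step beyond the scatter is expected, and the data favour no direction. The estimated step is a 1.3-fold lower number from compound 1 to compound 3 (0.10 log units; within the scatter) and its uncertainty is large. Compound 3 is estimated at 700 nM with an expected range of 150 nM to 3000 nM in this measurement.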

Compound 3, half-maximal inhibitory concentration: 14 nM
Estimate against measurement, compound 3: 50-fold (1.70 log units) above, outside the stated range (below it).
By their numbers in this assay, from the lowest: compound 3; then compounds 1 and 2 (each within the scatter of the next).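

The carbonyl group at this aromatic carbon turns out to matter far more than the chain length did: in this assay, removing it gives a 64-fold lower number from compound 1 to compound 3 (1.80 log units; beyond the scatter), whereas lengthening the chain gave only a 1.1-fold higher number from compound 1 to compound 2 (0.04 log units; within the scatter). Compared with the longer-chain compound, the same kind of change gives a 70-fold lower number from compound 2 to compound 3 (1.84 log units; beyond the scatter), so the large drop appears from both carbonyl-bearing compounds, and compound 3 is the most potent of the three in this assay. Nothing measured on these groups explains the size of this drop.

The swap also shortens the group at this position and changes what links the chain to the ring, so these compounds cannot show whether the missing carbonyl group alone accounts for the drop or whether the new link and the chain work together. A longer chain on the same ether oxygen would test whether chain length still makes little difference without the carbonyl group, and an amine in place of that oxygen would show how much depends on the oxygen itself.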